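A few compounds are considered here, and "the series" means these few. Any claim that something is new, unique, unknown or untested is made for them only; others in the source may bear on it.

Compound 2 `Cc1cccc2c1N(CC(=O)O)C/C(=C\c1ccccc1Cl)C2=O` stands highest of the two numbers in an assay on HL-60 cells for inhibition of glutathione S-transferase P (Homo sapiens), read by spectrophotometry, tested at 20 uM (on this read-out higher numbers stand for more inhibition at the one concentration tested (going by the name of the read-out) and lower numbers for less inhibition), where compound 2 gives 51.9%. Within the data shown here, its only neighbour, compound 1 `Cc1cc(C)cc(/C=C2\CN(CC(=O)O)c3c(C)cccc3C2=O)c1`, gives 17.5% in this assay, and the single measured step is a number 34.4 percentage points higher from compound 1 to compound 2 (beyond the scatter). Compound 3 `Cc1cccc(/C=C2\CN(CC(=O)O)c3c(C)cccc3C2=O)c1` differs from compound 2 by 3-methylphenyl in place of 2-chlorophenyl on a double-bonded chain carbon bound to a double-bonded ring carbon. That one step bears on the change, since 3-methylphenyl is nearer to the 3,5-dimethylphenyl of compound 1 than to 2-chlorophenyl. Compound 3 is therefore expected to drop, a number 23.9 percentage points lower from compound 2 to compound 3 (beyond the scatter), because compound 1 gives 17.5%. Compound 3 is estimated at 28%, between 10% and 50%.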

Compound 3, a percentage reported as inhibition, at one concentration (the size of the read-out at that concentration, not a potency): 39.1%
Compound 3: middle estimate off by 11.1 percentage points, on the low side, and the stated range covers the measured number.
By their numbers in this assay, from the lowest: compound 1; then compound 3; then compound 2.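

In this assay, 3-methylphenyl in place of 2-chlorophenyl gives a number 12.8 percentage points lower from compound 2 to compound 3 (beyond the scatter), so a methyl-bearing phenyl at this place can still hold a good part of the inhibition. Hydrogen in place of one methyl on the aromatic carbon gives a number 21.6 percentage points higher from compound 1 to compound 3 (beyond the scatter), which shows that the second methyl of compound 1 goes with the lower number. Nothing available here accounts for either step. As far as these compounds go, it stays open whether 2-methylphenyl or 3-chlorophenyl would separate the kind of group from its place on the ring, and what a methoxy group or an amine would give there.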